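Indole thioureas: para substituent swap in peroxidase inhibition

This account rests on a few compounds, and the source may have more. Where it says the series, first, only, none or still open, it means among the compounds named here.

Measured so far in an ADME assay on isolated protein for inhibition of peroxidase (Raphanus sativus), read by fluorescence and Amplex Red, tested at 5 uM; a lower number here means a stronger effect, a higher number a weaker effect of the compound at the concentration tested:
compound 1, `S=C(Nc1ccccc1)Nc1ccc2[nH]ccc2c1`: 81.4%
compound 2, `OCc1ccc(NC(=S)Nc2ccc3[nH]ccc3c2)cc1`: 88.3%

Compound 2 stands highest of the two numbers in this assay, with compound 1 nearest, but the only measured step, a number 6.9 percentage points higher from compound 1 to compound 2 (within the scatter), is within the scatter, so the two compounds cannot be ordered on the numbers shown.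

Compound 3, `COc1ccc(NC(=S)Nc2ccc3[nH]ccc3c2)cc1`, is not yet measured. It differs from compound 2 as follows:
methoxy in place of hydroxymethyl on an aromatic carbon

The step from compound 1 to compound 2 is the only one that bears on this change, since it concerns the same position on the same six-membered ring of the shared core, and it produced no movement beyond the scatter. Compound 3 keeps the same heavy atoms as compound 2, joined differently, so nothing measured suggests a step beyond the scatter in this assay in either direction.

Compound 3 is therefore expected to give about 85% in this assay, within 72% to 96%, the expected step being a number 3.3 percentage points lower from compound 2 to compound 3 (within the scatter).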

Compound 3, a percentage reported as activity, at one concentration (the size of the read-out at that concentration, not a potency): 67.6%
Beside the measured number, compound 3's estimate is 17.4 percentage points above it; the whole stated range lies above it.
By their numbers in this assay, from the lowest: compound 3; then compounds 1 and 2 (each within the scatter of the next).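

In this assay, this place on the six-membered aromatic ring, para to a large group, proves sensitive to the group it carries: methoxy in place of hydroxymethyl gives a number 20.7 percentage points lower from compound 2 to compound 3 (beyond the scatter), and methoxy in place of hydrogen gives a number 13.8 percentage points lower from compound 1 to compound 3 (beyond the scatter), whereas hydroxymethyl in place of hydrogen gave only a number 6.9 percentage points higher from compound 1 to compound 2 (within the scatter). Methoxy and hydroxymethyl have the same heavy atoms joined differently, with 0 and 1 hydrogen-bond donors, so the same atoms at one place can give numbers beyond the scatter of each other, and compound 3 shows a stronger effect at the tested concentration than either compound 1 or compound 2. No measurement offered here bears on what lies behind this difference.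

From the compounds shown here alone, compound 3 still reads 67.6%, so it remains open whether ethoxy or another longer chain would take the number lower than methoxy does, or whether an amine or a carboxylic acid at this place would do the same. The compounds shown also leave open whether the methoxy step holds on the shared core when the group sits elsewhere on this ring.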